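The compounds below may be only part of what the source reports. "The series", "measured", "known", "first", "only" and "open" are said of these compounds alone.

Compound 1, `O=c1cc(-c2ccccc2)c(NCc2ccccc2)n[nH]1`: > 10000 nM in an assay for inhibition of casein kinase I isoform alpha (Sus scrofa), read by scintillation counting and 33P incorporation, with a stated time of 30 min, in the presence of a further agent that is not named here (a lower number here means a stronger inhibitor, a higher number a weaker inhibitor), which is a limit of the assay.
Compound 2, `CCCNc1n[nH]c(=O)cc1-c1ccccc1`: > 10000 nM in this assay, likewise a limit.

Compound 2 stands at the limit of the assay; its value in this assay is not a number but a boundary. For the measured compounds named here, the one measured step, a step that the two limits leave unreadable from compound 1 to compound 2, runs between two limits and its size cannot be read, so it says nothing about how large a change on this part of the chain can be. Both measured values sit at the limit of > 10000 nM in this assay, at which 2 of the 2 values shown sit. Compound 3, `O=c1cc(-c2ccccc2)c(NCCN2CCCCC2)n[nH]1`, differs from compound 2 in one place: piperidin-1-yl in place of methyl on a saturated chain carbon, two bonds along the chain from a nitrogen on an aromatic ring. Going by the values given here, no measured step bears directly on this change; the only step on record is unreadable. What is known is that compound 2 gives only a limit, and that the shared core has twice reached only the limit. The expectation for compound 3 therefore rests on little; the step of a number no higher from compound 2 to compound 3 (the limit leaves the size open) is estimated as none beyond the scatter. Compound 3 is expected to give about 10000 nM, with a range from 3000 nM to 30000 nM, and most likely again only a limit.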

Compound 3, half-maximal inhibitory concentration: > 10000 nM
Compound 3: only a limit was reported; the forecaster's own chance of this, stated with the estimate: 75%; the middle value lies on the limit itself.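

In this assay compound 3 gives > 10000 nM, which is a limit of the assay. For the compounds shown here, no step among compound 1, compound 2 and compound 3 can therefore be read: the limit of > 10000 nM in this assay, at which 3 of the 3 values shown sit. The compounds shown leave open how strongly any of the three inhibits the enzyme, and whether changing the group on this chain alters inhibition at all.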